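The source may report more compounds than this note shows. Statements on the series, on what has been measured and on what is new or still open speak of the compounds shown alone.

Compound 1 `CCCOC(=O)C1=C(C)NC(=O)NC1c1cccs1` and compound 2 `CC1=C(C(=O)OCC(C)C)C(c2cccs2)NC(=O)N1` share one core and differ only by methyl in place of hydrogen on a saturated chain carbon bound to two saturated chain carbons on the ester chain. In an assay on membranes from CHO cells for displacement of a labelled ligand from adenosine receptor A1 (Homo sapiens), read by scintillation counting, with a stated time of 60 min, tested at 1 uM (on this read-out lower numbers stand for less inhibition and higher numbers for more inhibition at the one concentration tested (going by the name of the read-out)), compound 1 gives 43% and compound 2 gives 25% in the same test. That single change thus made a step of a number 18 percentage points lower from compound 1 to compound 2 (beyond the scatter) in this test. Compound 3 `CCCOC(=O)C1=C(C)NC(=S)NC1c1ccco1` has a different core, and the difference between the two cores is not broken down here. In this test compound 3 gives 1% and so stands lowest of the three numbers. Compound 4 `CC1=C(C(=O)OCC(C)C)C(c2ccco2)NC(=S)N1` differs from compound 3 by methyl in place of hydrogen on a saturated chain carbon bound to two saturated chain carbons at the same place as before. A step as large as the earlier one cannot repeat here because compound 3 gives 1% and the scale cannot fall much further. Compound 4 is therefore expected to show only a step of a number 1 percentage points higher from compound 3 to compound 4 (within the scatter) in this test. Compound 4 is estimated to give 2% with a likely range from 0% to 12% in this test.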

Compound 4, a percentage reported as inhibition, at one concentration (the size of the read-out at that concentration, not a potency): 7%
The estimate for compound 4 lay 5 percentage points below the measured number; measured number inside the range.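

On the core of compound 3, going from propyl to isobutyl gave a number 6 percentage points higher from compound 3 to compound 4 (within the scatter) in this assay, so the fall seen on the core of compound 1 did not carry over to this second core. The two steps differ: the same change on two cores in this assay, a number 18 percentage points lower (beyond the scatter) from compound 1 to compound 2 and a number 6 percentage points higher (within the scatter) from compound 3 to compound 4, 24 percentage points apart, beyond the scatter of two such steps. This does not show why they differ: the two cores are not broken down into their separate differences, and compound 3 already gives 1%, which leaves little room on the scale for any fall.

The compounds shown leave open how a longer chain such as butyl, or an ester chain ending in an amine, would read in this test. They also leave open whether the change behaves the same way on any further core.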